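Ring nitrogen and hydroxyl position on a trisubstituted pyridine core

A few compounds are considered here, and "the series" means these few. Any claim that something is new, unique, unknown or untested is made for them only; others in the source may bear on it.

Three compounds sharing one core have numbers in an assay on isolated protein for inhibition of DNA topoisomerase 1 (Homo sapiens), with a stated time of 30 min, tested at 100 uM; on this read-out higher numbers stand for a stronger effect at the one concentration tested and lower numbers for a weaker effect. Compound 2 `Oc1cccc(-c2cc(-c3ccccc3)nc(-c3ccc(Cl)cc3)c2)c1` gives 7.1%. Compound 1 `Oc1cccc(-c2cc(-c3ccc(Cl)cc3)nc(-c3ccccn3)c2)c1` gives 30%. Compound 3 `Oc1ccc(-c2cc(-c3ccccc3)nc(-c3ccc(Cl)cc3)c2)cc1` gives 68% and stands highest of the three, its distance to compound 1 and to compound 2 both beyond the scatter.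

Two single changes connect these. From compound 2 to compound 1 the change is pyridin-2-yl in place of phenyl on an aromatic carbon, and the step is a number 22.9 percentage points higher from compound 2 to compound 1 (beyond the scatter). From compound 2 to compound 3 the two cores differ as 4-hydroxyphenyl in place of 3-hydroxyphenyl on an aromatic carbon, and the step is a number 60.9 percentage points higher from compound 2 to compound 3 (beyond the scatter); this is the larger of the two moves.

Compound 4 `Oc1ccc(-c2cc(-c3ccc(Cl)cc3)nc(-c3ccccn3)c2)cc1` is not yet measured. Relative to compound 3 it carries pyridin-2-yl in place of phenyl on an aromatic carbon. Among the measured compounds shown here, this is the same kind of change as the one from compound 2 to compound 1, not the same one: there the place was meta to a 3-hydroxyphenyl group and meta to a 4-chlorophenyl group, here it is meta to a 4-chlorophenyl group and meta to a 4-hydroxyphenyl group.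

For compound 3 to compound 4 in this assay a step of a number 17 percentage points higher from compound 3 to compound 4 (beyond the scatter) is expected, resting on the earlier step of a number 22.9 percentage points higher from compound 2 to compound 1 (beyond the scatter) and on the high starting point of compound 3 at 68%, which leaves less room upward than compound 2 had. Compound 4 is accordingly estimated at 85%, with a likely range from 65% to 98%.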

Compound 4, a percentage reported as inhibition, at one concentration (the size of the read-out at that concentration, not a potency): 12.7%
The estimate for compound 4 lay 72.3 percentage points above the measured number; the whole stated range lies above it.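

In this assay, pyridin-2-yl in place of phenyl gives a number 55.3 percentage points lower from compound 3 to compound 4 (beyond the scatter), so on the core carrying 4-hydroxyphenyl this change runs opposite to its direction on the core carrying 3-hydroxyphenyl, and its sign does not carry from one core to the other: the same change on two cores in this assay, a number 22.9 percentage points higher (beyond the scatter) from compound 2 to compound 1 and a number 55.3 percentage points lower (beyond the scatter) from compound 3 to compound 4, 78.2 percentage points apart, beyond the scatter of two such steps

The hydroxyl move reverses in the same way, with 4-hydroxyphenyl in place of 3-hydroxyphenyl giving a number 17.3 percentage points lower from compound 1 to compound 4 (beyond the scatter) once pyridin-2-yl is present, so neither change can be read as a fixed increment in this series: the same change on two cores in this assay, a number 60.9 percentage points higher (beyond the scatter) from compound 2 to compound 3 and a number 17.3 percentage points lower (beyond the scatter) from compound 1 to compound 4, 78.2 percentage points apart, beyond the scatter of two such steps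

These four compounds form one closed square, so the two comparisons describe a single dependence between the two places rather than two independent findings, and single-concentration percentages of this kind show neither a potency order nor a reason for the reversal.

Open, going by these compounds, is whether the reversal is tied to the hydroxyl itself, which a methoxy or an amine at the same place on that ring would test. Also open, on these data alone, is whether it is tied to the ring nitrogen of pyridin-2-yl or would recur with another group there, such as a carboxylic acid on the phenyl ring.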